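Nitro to Cyano: What the Numbers Allow

The source may report more compounds than this note shows. Statements on the series, on what has been measured and on what is new or still open speak of the compounds shown alone.

Measured compounds:
compound 1, `CCOC(=O)c1ccc(Nc2ccnc(SCC(=O)c3ccc([N+](=O)[O-])cc3)n2)cc1`, 33%
compound 2, `O=C(O)c1ccc(Nc2ccnc(SCC(=O)c3ccc(C(F)(F)F)cc3)n2)cc1`, 12%

In a functional assay on PC-3 cells (Homo sapiens) for inhibition, read by sulforhodamine B assay, with a stated time of 48 h, tested at 10 uM (on this read-out lower numbers stand for less inhibition of growth and higher numbers for more inhibition of growth at the one concentration tested), compound 1 stands highest of the two numbers shown. Its nearest neighbour, compound 2, gives 12%, a number lower by a gap that lies beyond the scatter. Among the compounds with values here, compound 2 differs from compound 1 in more than one place, so no single step between measured compounds is drawn from that pair; only the two values themselves are known.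

Compound 3, `CCOC(=O)c1ccc(Nc2ccnc(SCC(=O)c3ccc(C#N)cc3)n2)cc1`, has not yet been measured. It differs from compound 1 by cyano in place of nitro on an aromatic carbon. Within the data shown here, no step between measured compounds isolates this change, so the account rests on compound 1 alone. With one acceptor fewer at the same place, a small downward step is the more likely outcome, though a step within the usual scatter, or none at all, cannot be ruled out.

Compound 3 is therefore expected to give 26% in this assay, with a range from 10% to 42%. The step expected a number 7 percentage points lower from compound 1 to compound 3 (within the scatter) is modest and downward.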

Compound 3, percent growth inhibition at one concentration: 60%
Estimate against measurement, compound 3: 34 percentage points below, outside the stated range (above it).
By their numbers in this assay, from the lowest: compound 2; then compound 1; then compound 3.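

Within the data shown here, the measured step at this position is a number 27 percentage points higher from compound 1 to compound 3 (beyond the scatter) in this assay, and it is the first comparison here that isolates a single place, as compound 1 and compound 2 differ in more than one. It shows that the group on the aromatic carbon, para to a large group, matters to the read-out, since cyano in place of nitro alone moves the number by more than the usual scatter. It also shows that the nitro group is not needed for growth inhibition in this series, although nothing at hand explains why the change from 4-nitrophenyl to 4-cyanophenyl raises the number.

Going by these compounds, whether this position would accept a quite different group, such as an amine or a longer chain ending in a nitrile, remains open. It is equally unknown whether cyano in place of nitro would give a similar step on a core carrying a carboxylic acid instead of the ester of compound 1, and whether the step would hold at other concentrations.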